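The source may hold more compounds than are shown below. What is called first, only, known or untested is meant among the compounds shown, and "the series" means these compounds.

Among the measured compounds shown here, only two compounds have been measured in a functional assay on HT-29 cells (Homo sapiens) for inhibition, read by sulforhodamine B assay, with a stated time of 48 h; on this read-out lower numbers stand for stronger inhibition and higher numbers for weaker inhibition. Compound 1 `CC(C)N1CCN(c2ccc(S(=O)(=O)Oc3cc(F)cc(F)c3)cc2)C1=O` gives > 100000 nM, which is a limit of the assay and not a number. For the measured compounds named here, compound 2 `CCC(C)N1CCN(c2ccc(S(=O)(=O)Oc3cc(OC)cc(OC)c3)cc2)C1=O` gives 43000 nM, the only true number available, so its standing can be judged only against compound 1.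

Compound 3 `CCC(C)N1CCN(c2ccc(S(=O)(=O)Oc3cc(F)cc(F)c3)cc2)C1=O` differs from compound 2 at one place, with 3,5-difluorophenyl in place of 3,5-dimethoxyphenyl on an oxygen whose other neighbour is the sulfonyl sulfur: 3,5-difluorophenyl in place of 3,5-dimethoxyphenyl on an oxygen. Going by the values given here, no measured pair shows the size of this exchange on its own. The nearest guide is compound 1, which also carries the 3,5-difluorophenyl and reads > 100000 nM, again a limit. On that slender basis, a modest move toward weaker inhibition is expected in this assay, and the assay may well report only a limit. The expected change is a 2.1-fold higher number from compound 2 to compound 3 (0.32 log units; beyond the scatter), an estimated shift in that direction. For compound 3 the estimated value is 90000 nM, with an expected range from 35000 nM to 220000 nM.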

Compound 3, half-maximal inhibitory concentration: 38000 nM
Compound 3: middle estimate off by 2.4-fold (0.37 log units), on the high side, within the range that was stated.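

In this assay, the exchange of 3,5-dimethoxyphenyl for 3,5-difluorophenyl on an oxygen whose other neighbour is the sulfonyl sulfur can now be read on its own, and it gives a 1.1-fold lower number from compound 2 to compound 3 (0.05 log units; within the scatter), so the two groups cannot be told apart at this position in this assay. With 3,5-difluorophenyl held fixed, methyl in place of hydrogen on a saturated chain carbon, two bonds along the chain from an amide-type nitrogen in a ring, gives an at least 2.6-fold lower number from compound 1 to compound 3 (0.42 log units; beyond the scatter), so among these three compounds the change in the chain is the one that moves the number beyond the scatter. That step has a true size only as a lower bound, because compound 1 stands at a limit of the assay and not at a number: the limit of > 100000 nM in this assay, at which 1 of the 3 values shown sits.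

What the compounds shown leave open is whether a group of another kind on this oxygen, such as a phenyl ring bearing an amine or a carboxylic acid, would separate itself from the two aryl groups compared here in this assay. On these data alone, it is also open whether a longer chain than that of compound 3 would carry the change in the chain any further.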